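The source may hold more compounds than are shown below. What is called first, only, known or untested is meant among the compounds shown, and "the series" means these compounds.

Compound 1 `CC(C)(C)OC(=O)N1CCC(CCOC(=O)N2CCc3cc(S(C)(=O)=O)cc(F)c32)CC1`: 25 nM
Compound 2 `Cc1cc(S(C)(=O)=O)cc2c1N(C(=O)OCCC1CCN(C(=O)OC(C)(C)C)CC1)CC2`: 44 nM

In a functional assay on CHO cells for agonist activity at Glucose-dependent insulinotropic receptor (Homo sapiens), read by a luciferase reporter and cAMP accumulation, with a stated time of 2 h (a lower number here means that less compound is needed, a higher number that more compound is needed for the effect), compound 2 gives the higher of the two numbers, yet the step of a 1.8-fold higher number from compound 1 to compound 2 (0.25 log units; within the scatter) lies within the scatter, so the two compounds cannot be told apart. Compound 3 `COc1cc(S(C)(=O)=O)cc2c1N(C(=O)OCCC1CCN(C(=O)OC(C)(C)C)CC1)CC2` differs from compound 2 by methoxy in place of methyl on an aromatic carbon on an aromatic carbon of the shared core. Going by the values given here, no measured step bears directly on this change; the only measured step, a 1.8-fold higher number from compound 1 to compound 2 (0.25 log units; within the scatter), is a change at the same place that stayed within the scatter. Compound 3 is therefore expected to show no step beyond the scatter, a 1.1-fold higher number from compound 2 to compound 3 (0.06 log units; within the scatter), with an estimated value of 50 nM (range 15 nM to 160 nM).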

Compound 3, half-maximal effective concentration in the Glucose-dependent insulinotropic receptor assay: 1700 nM
For compound 3 the middle estimate is 34-fold (1.53 log units) below the measured one, and the stated range ends below it.
By their numbers in the Glucose-dependent insulinotropic receptor assay, from the lowest: compounds 1 and 2 (each within the scatter of the next); then compound 3.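

In the Glucose-dependent insulinotropic receptor assay this position, where fluoro and methyl could not be told apart, proves sensitive: compound 3 gives 1700 nM, and methoxy brings a 39-fold higher number from compound 2 to compound 3 (1.59 log units; beyond the scatter) and a 68-fold higher number from compound 1 to compound 3 (1.83 log units; beyond the scatter) although methoxy has 2 heavy atoms (1 carbon, 1 oxygen) where methyl has 1 heavy atom (1 carbon). In a physicochemical assay for solubility, read by HPLC, at pH 6.8 (a lower number here means a less soluble compound, a higher number a more soluble compound), the same swap gives only a 1.5-fold higher number from compound 2 to compound 3 (0.16 log units; within the scatter) so there compound 2, at 44 ug/mL, and compound 3, at 64 ug/mL, cannot be told apart. No available evidence explains the large step in receptor activation.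

From the compounds shown here alone, whether a hydroxyl, an ethoxy or an amine at this position would behave like methoxy or like methyl stays open.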